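The source may hold more compounds than are shown below. What is called first, only, known or untested is meant among the compounds shown, and "the series" means these compounds.

Compound 1 `CNCCN(C)c1nnnn1Cc1ccc(OC(F)(F)F)cc1` and compound 2 `CNCCN(C)c1nnnn1Cc1ccc(OC)cc1` share one core, and compound 3 `CN(CCN)Cc1ccc(-c2ccc(OC(F)(F)F)cc2)o1` is built on a different core; how the two cores differ is not broken down here. In an assay on cells for inhibition of protein arginine N-methyltransferase 1 (Homo sapiens), read by scintillation counting, with stated times of 15 min and 60 min, tested at 9 uM (on this read-out higher numbers stand for more inhibition at the one concentration tested (going by the name of the read-out) and lower numbers for less inhibition), compound 1 gives 5%, compound 2 gives 0%, and compound 3 gives 25%. The change methyl in place of trifluoromethyl on an oxygen on an aromatic ring made a number 5 percentage points lower from compound 1 to compound 2 (within the scatter). Compound 4 `COc1ccc(-c2ccc(CN(C)CCN)o2)cc1` carries the same change on the core of compound 3, namely (methyl in place of trifluoromethyl on an oxygen on an aromatic ring), at the same place in both pairs. Because the step of a number 5 percentage points lower from compound 1 to compound 2 (within the scatter) stayed within the scatter, the step from compound 3 to compound 4 is expected to be small as well, about a number 7 percentage points lower from compound 3 to compound 4 (within the scatter) in this assay. On that basis compound 4 is estimated to give around 18%, with a likely range from 4% to 32%.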

Compound 4, a percentage reported as inhibition, at one concentration (the size of the read-out at that concentration, not a potency): 25%
Compound 4: middle estimate off by 7 percentage points, on the low side; the range from low to high includes it.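

In this assay the swap of trifluoromethoxy to methoxy shows no change at the digits printed from compound 3 to compound 4 (within the scatter) on the core of compound 3. Set beside the earlier pair, the swap reads alike on both cores: the same change on two cores in this assay, a number 5 percentage points lower (within the scatter) from compound 1 to compound 2 and no change at the digits printed (within the scatter) from compound 3 to compound 4, 5 percentage points apart, within the scatter of two such steps. This shows that, in these two pairs, the change carries from one core to the other with small steps on both, but it does not show that the two groups are interchangeable on other cores, since the evidence is two pairs tested at one concentration.

Going by these compounds, it remains open what would happen with an amine or a carboxylic acid in place of these groups on the aromatic ring. A longer chain on that oxygen is also left open.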